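Iodo to hydroxy on the shared core

A few compounds are considered here, and "the series" means these few. Any claim that something is new, unique, unknown or untested is made for them only; others in the source may bear on it.

Compound 1 `Nc1nc2c(nc(I)n2COCCO)c(=O)[nH]1`: 111000 nM
Compound 2 `Nc1ncnc2c1ncn2C1CC(O)C(/C=N/O)O1`: 17400 nM

In an ADME assay on L1210/0 cells (Mus musculus) for cytotoxicity, with a stated time of 48 h (a lower number here means a stronger inhibitor, a higher number a weaker inhibitor), compound 1 holds the higher of the two numbers, and compound 2 lies lower by more than the scatter. Compound 3 `Nc1nc2c(nc(O)n2COCCO)c(=O)[nH]1` carries hydroxy in place of iodo on an aromatic carbon. Going by the values given here, no measured step covers this change, and compound 1 and compound 2 differ in more than one place. A step beyond the scatter is not expected in either direction. The estimated step is a 1.1-fold higher number from compound 1 to compound 3 (0.03 log units; within the scatter). For compound 3 the expected value is 120000 nM, with an estimated range of 45000 nM to 350000 nM.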

Compound 3, half-maximal inhibitory concentration: > 200000 nM
Compound 3 was reported as a limit; the forecaster's own chance of this, stated with the estimate: 40%; middle value at least 1.6-fold (0.22 log units) from the limit.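

In this assay, the change from iodo to hydroxy on the aromatic carbon between two ring nitrogen atoms gives an at least 1.8-fold higher number from compound 1 to compound 3 (0.25 log units; that floor lies within the scatter). This position therefore gains no lower number from hydroxy. The value of compound 3 is a limit and not a number, so the full size of the step remains unknown: the limit of > 200000 nM in this assay, at which 1 of the 3 values shown sits.

Going by these compounds, whether an amine or a methyl group on this carbon would give a lower number than iodo stays open. So does whether the same change would behave alike with a longer chain in place of the (2-hydroxyethoxy)methyl group.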